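Cytotoxicity in Human Fibroblasts: From Compound 1 to Compound 3

The compounds below may be only part of what the source reports. "The series", "measured", "known", "first", "only" and "open" are said of these compounds alone.

Compound 1 `CC1=C([Se]CC(OC(=O)[C@@H](CO)NC(=O)OC(C)(C)C)C(=O)NCCCCCC(=O)OCc2ccccc2)C(=O)c2ccccc2C1=O`: 27000 nM
Compound 2 `CC1=C(SCCC(=O)OC(C[Se]c2ccccc2)C(=O)NC(C)(C)C)C(=O)c2ccccc2C1=O`: 26000 nM

In an ADME assay on PHF cells (Homo sapiens) for cytotoxicity, read by MTT assay, with a stated time of 24 h (a higher number here means a weaker inhibitor, a lower number a stronger inhibitor), compound 1 stands at the higher of the two numbers, yet its gap to compound 2 is within the scatter, so the two compounds read alike. Compound 3 `CC1=C([Se]CC(OC(=O)CC[Se]c2ccccc2)C(=O)NCCCCCC(=O)OCc2ccccc2)C(=O)c2ccccc2C1=O` has not been measured. It differs from compound 1 by a group of 9 heavy atoms (8 carbon, 1 selenium; one six-membered aromatic ring of carbon only) in place of a group of 11 heavy atoms (7 carbon, 1 nitrogen, 3 oxygen; no ring), on a carbonyl carbon. Going by the values given here, no measured pair shows this kind of change, so nothing here points to a step beyond the scatter in either direction. Compound 3 is therefore expected to give 25000 nM (range 12000 nM to 55000 nM), a step of a 1.1-fold lower number from compound 1 to compound 3 (0.03 log units; within the scatter).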

Compound 3, half-maximal inhibitory concentration: 6000 nM
Estimate against measurement, compound 3: 4.2-fold (0.62 log units) above; measured number outside the range, below it.
By their numbers in this assay, from the lowest: compound 3; then compounds 2 and 1 (each within the scatter of the next).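

In this assay the position on the carbonyl carbon proves able to move the reading: putting the selenium-bearing group with its six-membered aromatic ring in place of 2-hydroxy-1-((tert-butoxycarbonyl)amino)ethyl gives a 4.5-fold lower number from compound 1 to compound 3 (0.65 log units; beyond the scatter) beyond the scatter. Nothing available bears on what lies behind this step. Still open, from the compounds shown here alone, is whether the selenium or the aromatic ring carries the step, since both enter together. A sulfur atom in place of that selenium, or an amine on the same carbonyl carbon, would bear on this.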